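Replacing Fluoro with Methoxy on a Shared Core

The compounds below may be only part of what the source reports. "The series", "measured", "known", "first", "only" and "open" are said of these compounds alone.

Three measured compounds share one core and differ at a single aromatic carbon. In a functional assay with sulfonylurea receptor 1, Kir6.2 (Homo sapiens) as the target (on this read-out higher numbers stand for an effect only at larger amounts of compound and lower numbers for an effect already at smaller amounts), compound 1 `Nc1ccc2c(c1)S(=O)(=O)NC(NC1CCC1)=N2` gives 31600 nM, compound 2 `O=S1(=O)N=C(NC2CCC2)Nc2ccccc21` gives 2000 nM, and compound 3 `O=S1(=O)NC(NC2CCC2)=Nc2ccc(F)cc21` gives 398 nM. Compound 3 stands lowest of the three, with compound 2 nearest and compound 1 furthest. Among the measured compounds shown here, the only measured step at this carbon, a 79-fold lower number from compound 1 to compound 3 (1.90 log units; beyond the scatter), is large. Compound 4 `COc1ccc2c(c1)S(=O)(=O)NC(NC1CCC1)=N2` carries the change (methoxy in place of fluoro on an aromatic carbon). For the measured compounds named here, no measured step leads from fluoro to methoxy, and compound 2, unsubstituted at that carbon, lies between compound 1 and compound 3. A rise from compound 3 is therefore expected, a 4.0-fold higher number from compound 3 to compound 4 (0.60 log units; beyond the scatter), though smaller than the step from compound 1. Compound 4 is estimated at 1600 nM, within 300 nM to 8000 nM.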

Compound 4, half-maximal effective concentration: 3980 nM
The estimate for compound 4 lay 2.5-fold (0.40 log units) below the measured number; the measured number falls inside the stated range.
By their numbers in this assay, from the lowest: compound 3; then compounds 2 and 4 (each within the scatter of the next); then compound 1.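

In this assay, methoxy in place of fluoro gives a 10-fold higher number from compound 3 to compound 4 (1.00 log units; beyond the scatter), while methoxy in place of amino gives a 7.9-fold lower number from compound 1 to compound 4 (0.90 log units; beyond the scatter), so this carbon orders the three groups as fluoro, methoxy, amino. Compound 4 lies within the scatter of compound 2, which is unsubstituted at that carbon, whereas compound 3 stands beyond the scatter of compound 2. Nothing available here explains these steps. From the compounds shown here alone, whether chloro, a carboxylic acid or a longer chain such as ethoxy at this carbon would fit that order remains open.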